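The compounds below may be only part of what the source reports. "The series", "measured", "known", "first", "only" and "open" are said of these compounds alone.

Compound 1 `CC1(C)C=C(n2ccccc2=O)c2ccccc2O1` gives 5.43 in a functional assay (aorta) with Rattus norvegicus as the target; a higher number here means a more potent compound, by a factor of ten per unit of this negative logarithm, a lower number a less potent compound. Compound 2 `CC1(C)C=C(n2ccccc2=O)c2cc(C(=O)c3ccccc3)ccc2O1` gives 6.61 in this assay. Compound 3 `CC1(C)C=C(n2ccccc2=O)c2cc(O)ccc2O1` gives 5.44 in this assay.

Compound 3 stands second of the three, with compound 1 nearest (a number 0.01 log units higher from compound 1 to compound 3 (within the scatter)) and compound 2 furthest (a number 1.17 log units lower from compound 2 to compound 3 (beyond the scatter)). Compound 4 `CC1(C)C=C(n2ccccc2=O)c2cc(OC(=O)Nc3ccccc3F)ccc2O1` differs from compound 3 by (2-fluorophenyl)carbamoyl in place of hydrogen on an oxygen on an aromatic ring. The step that bears on this is a number 1.18 log units higher from compound 1 to compound 2 (beyond the scatter), where a large aromatic group entered the core; the hydroxy step a number 0.01 log units higher from compound 1 to compound 3 (within the scatter) was flat. A sizeable rise in this assay is therefore expected, though the group enters on an oxygen rather than a carbon. Compound 4 is estimated at 6.3, between 5.6 and 7, a step of a number 0.86 log units higher from compound 3 to compound 4 (beyond the scatter).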

Compound 4, logarithm of the reciprocal of the active concentration, log(1/C): 5.38
Estimate against measurement, compound 4: 0.92 log units above; the whole stated range lies above it.
By their numbers in this assay, from the lowest: compounds 4, 1 and 3 (each within the scatter of the next); then compound 2.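

In this assay the step of a number 0.06 log units lower from compound 3 to compound 4 (within the scatter) shows that (2-fluorophenyl)carbamoyl on the oxygen on an aromatic ring, which brings its own six-membered aromatic ring, leaves the two numbers within the scatter of each other. An aromatic ring entering at this place therefore does not by itself bring a rise like the step of a number 1.18 log units higher from compound 1 to compound 2 (beyond the scatter) seen with benzoyl on carbon. No measurement here explains this result. Still open, as far as these compounds go, is how a simple acetyl or a longer alkyl chain on this oxygen would read, and whether an amine in place of the oxygen would give the same number.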